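Working notes: one more methoxy on compound 2

The compounds below may be only part of what the source reports. "The series", "measured", "known", "first", "only" and "open" are said of these compounds alone.

Compound 1 `COc1cc(/C=C/C(=O)c2c(OC)cc(O)c(CC=C(C)C)c2O)ccc1O`: 11800 nM
Compound 2 `COc1ccc(/C=C/C(=O)c2c(OC)cc(O)c(CC=C(C)C)c2O)cc1OC`: 15700 nM

In a functional assay on A549 cells (Homo sapiens) for inhibition, read by MTT assay, with a stated time of 72 h (on this read-out higher numbers stand for weaker inhibition and lower numbers for stronger inhibition), compound 2, at 15700 nM, stands level with compound 1 within the scatter, so neither can be ranked above the other. Compound 3 `COc1cc(OC)c(OC)cc1/C=C/C(=O)c1c(OC)cc(O)c(CC=C(C)C)c1O` differs from compound 2 by methoxy in place of hydrogen on an aromatic carbon. For the measured compounds named here, only one measured step bears on this, and only indirectly: methyl in place of hydrogen on an oxygen on an aromatic ring, a 1.3-fold higher number from compound 1 to compound 2 (0.12 log units; within the scatter). Going by the values given here, no measured step shows a methoxy entering on an aromatic carbon. With that single small step as the guide, no shift beyond the scatter is expected in this assay, and no direction can be favoured. The expected step is a 1.1-fold lower number from compound 2 to compound 3 (0.05 log units; within the scatter). For compound 3 the estimated value is 14000 nM, with an expected range from 6000 nM to 30000 nM.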

Compound 3, half-maximal inhibitory concentration: 14400 nM
For compound 3 the middle estimate is 1.0-fold (0.01 log units) below the measured one; the range from low to high includes it.
By their numbers in this assay, from the lowest: compounds 1, 3 and 2 (each within the scatter of the next).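

On this aromatic carbon, ortho to a large group, meta to a methoxy group and para to a methoxy group, compound 2 carries hydrogen and compound 3 carries methoxy. In this assay this exchange gives a 1.1-fold lower number from compound 2 to compound 3 (0.04 log units; within the scatter), so this position now has a direct reading of its own, whereas the earlier step concerned only methyl in place of hydrogen on an oxygen. Nothing available explains the size of this step.

Open, on these data alone, is whether an amine or a carboxylic acid on the same aromatic carbon would give a step beyond the scatter. Also open, as far as these compounds go, is whether a longer chain on the oxygen of the entering methoxy would stay within the scatter of compound 2 in the same read-out.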